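Aryl imine series: hydroxy for fluoro on the pendant ring

A few compounds are considered here, and "the series" means these few. Any claim that something is new, unique, unknown or untested is made for them only; others in the source may bear on it.

Compound 1 `Nc1sc2c(c1-c1nc3ccccc3s1)CCCC2` gives 163 ug/mL in an ADME assay on HepG2 cells (Homo sapiens) for cytotoxicity, read by MTT assay, with a stated time of 72 h; on this read-out lower numbers stand for higher toxicity in this test and higher numbers for lower toxicity in this test. Compound 2 `Nc1sc2c(c1-c1nc3cc(Cl)ccc3s1)CCCC2` gives 93.7 ug/mL; the step of a 1.7-fold lower number from compound 1 to compound 2 (0.24 log units; within the scatter) is the only one measured among these three. Compound 3 `Fc1ccccc1/C=N/c1sc2c(c1-c1nc3ccccc3s1)CCC2` gives 394 ug/mL and stands highest of the three numbers, beyond the scatter from both compound 1 and compound 2.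

Compound 4 `Oc1ccccc1/C=N/c1sc2c(c1-c1nc3ccccc3s1)CCC2` differs from compound 3 by hydroxy in place of fluoro on an aromatic carbon, on an aromatic carbon of a six-membered aromatic ring of carbon only. For the measured compounds named here, no measured step concerns this pendant ring; the single step from compound 1 to compound 2 changes a different position on the shared core and stays within the scatter, so it gives no direction for this change. With nothing bearing on the substitution, the expectation is for no step beyond the scatter in this assay.

Compound 4 is therefore estimated at 350 ug/mL, with a range from 150 ug/mL to 750 ug/mL. The estimated step from compound 3 to compound 4 is a 1.1-fold lower number from compound 3 to compound 4 (0.05 log units; within the scatter), expected to stay within the scatter.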

Compound 4, half-maximal cytotoxic concentration: 156 ug/mL
Compound 4: middle estimate off by 2.2-fold (0.35 log units), on the high side; low and high end bracket the measured number.
By their numbers in this assay, from the lowest: compounds 2, 4 and 1 (each within the scatter of the next); then compound 3.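

The pendant ring is not a silent position in this assay: hydroxy in place of fluoro, on an aromatic carbon ortho to a large group, gives a 2.5-fold lower number from compound 3 to compound 4 (0.40 log units; beyond the scatter) and so moves the imine series towards higher toxicity in this test. Unlike the chloro change on the shared core, which gives a 1.7-fold lower number from compound 1 to compound 2 (0.24 log units; within the scatter) and stays within the scatter, this change produces a step beyond the scatter, and it adds a hydrogen-bond donor and a hydrogen-bond acceptor where fluoro has neither. Nothing at hand explains the step.

Still open, as far as these compounds go, is whether the step depends on hydroxy itself, which a methoxy or an amine on the same ring carbon would test. Also open, from the compounds shown here alone, is whether the same change gives a similar step on a chloro-bearing core.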